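Dipropylamino to diethylamino on the shared core

The source may report more compounds than this note shows. Statements on the series, on what has been measured and on what is new or still open speak of the compounds shown alone.

Measured so far in an ADME assay on Vero cells (Chlorocebus sabaeus) for cytotoxicity, read by resazurin assay, with a stated time of 3 days; on this read-out higher numbers stand for weaker inhibition and lower numbers for stronger inhibition
- compound 1 `CCN(CC)c1cc2[nH]c(C3CCCCC3)nc2cc1NC(=O)c1ccc(N(C)C)cc1` gives "not determined" (no result reported)
- compound 2 `CCN(CC)c1cc2[nH]c(C3CCCCC3)nc2cc1NC(=O)OCC(F)(F)F` gives > 100 ug/mL (a limit)
- compound 3 `CCCCOC(=O)Nc1cc2nc(C3CCCCC3)[nH]c2cc1N(CCC)CCC` gives > 100 ug/mL (a limit)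

Compound 3 stands at > 100 ug/mL in this assay and this is a limit, not a number. The series offers the limit of > 100 ug/mL in this assay, at which 2 of the 3 values shown sit, and no number on which to base a step. Compound 4 `CCCCOC(=O)Nc1cc2nc(C3CCCCC3)[nH]c2cc1N(CC)CC` carries diethylamino in place of dipropylamino on an aromatic carbon with diethylamino in place of dipropylamino on an aromatic carbon. The expected size of a number no higher from compound 3 to compound 4 (the limit leaves the size open) is none beyond the scatter in this assay and no direction is expected. For compound 4 100 ug/mL is the estimated value, with 50 ug/mL to 200 ug/mL as its expected range.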

Compound 4, half-maximal inhibitory concentration: > 100 ug/mL
Compound 4 ended at the assay's limit; the forecaster's own chance of this, stated with the estimate: 75%; the middle value lies on the limit itself.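

In this assay compound 4 gives > 100 ug/mL, a limit and not a number. Within the data shown here, with compound 2 and compound 3 also at limits, no step to compound 4 can be read. The compounds shown leave open whether diethylamino and dipropylamino differ at all in this assay.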